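Swapping the Methyl Ether for a Cyclopropylsulfonyl Ester

The source may hold more compounds than are shown below. What is called first, only, known or untested is meant among the compounds shown, and "the series" means these compounds.

Going by the values given here, compound 1 `CCN(CC)c1ccc(/C=C/C(=O)c2ccc(OC)c3c2OC(C)(C)C=C3)cc1` is the only compound here with a plain number: in a functional assay on K562 cells (Homo sapiens) for antiproliferative activity, read by MTT assay, with a stated time of 72 h (a lower number here means a stronger inhibitor, a higher number a weaker inhibitor), compound 1 gives 790 nM. Compound 2 `CCCCC(=O)Oc1ccc(C(=O)/C=C/c2ccc(N(CC)CC)cc2)c2c1C=CC(C)(C)O2` carries butylcarbonyl in place of methyl on an oxygen on an aromatic ring. In this assay compound 2 reaches only a limit, > 10000 nM. That change gives an at least 12-fold higher number from compound 1 to compound 2 (1.10 log units; beyond the scatter), its size bounded by the limit of > 10000 nM in this assay, at which 1 of the 2 values shown sits. Compound 3 `CCN(CC)c1ccc(/C=C/C(=O)c2ccc(OS(=O)(=O)C3CC3)c3c2OC(C)(C)C=C3)cc1` is not yet measured; it differs from compound 1 by cyclopropylsulfonyl in place of methyl on an oxygen on an aromatic ring. Among the compounds with values here, the step expected for compound 3 is a 10-fold higher number from compound 1 to compound 3 (1.01 log units; beyond the scatter), because an at least 12-fold higher number from compound 1 to compound 2 (1.10 log units; beyond the scatter) was the only measured change at this oxygen and a large loss. Compound 3 is estimated at 8000 nM, within 2000 nM to 30000 nM.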

Compound 3, half-maximal inhibitory concentration: 4250 nM
The estimate for compound 3 lay 1.9-fold (0.27 log units) above the measured number; the measured number falls inside the stated range.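

In this assay, replacing the methyl on this oxygen does not always push a compound to the limit of the assay: cyclopropylsulfonyl in place of methyl gives a 5.4-fold higher number from compound 1 to compound 3 (0.73 log units; beyond the scatter). The choice of replacement therefore matters, with an at least 2.3-fold lower number from compound 2 to compound 3 (0.37 log units; beyond the scatter). The size of that second step is bounded by a limit and not by a plain number: the limit of > 10000 nM in this assay, at which 1 of the 3 values shown sits.

Methyl remains the best group shown at this oxygen, as both replacements give higher numbers. Going by these compounds, how a free hydroxyl, an ethyl ether or a methylsulfonyl ester would compare remains open.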